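Methyl scan on the aromatic ring: compound 1 to compound 3

The source may hold more compounds than are shown below. What is called first, only, known or untested is meant among the compounds shown, and "the series" means these compounds.

Values in an ADME assay on CHO cells (Cricetulus griseus) for inhibition, read by MTT assay; a lower number here means a stronger inhibitor, a higher number a weaker inhibitor:
- compound 1 `CCN(CC)Cc1cccc(Nc2nc3ccccc3n2Cc2ccc(C#N)cc2)c1O`: > 50000 nM (a limit of the assay, not a number)
- compound 2 `CCN(CC)Cc1cc(C)cc(Nc2nc3ccccc3n2Cc2ccc(C#N)cc2)c1O`: 14200 nM

In this assay compound 1 gives only a limit, > 50000 nM. Compound 1 therefore stands at the limit of > 50000 nM in this assay, at which 1 of the 2 values shown sits, so any step that starts from it has a known direction and only a bounded size.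

The open compound is compound 3 `CCN(CC)Cc1ccc(C)c(Nc2nc3ccccc3n2Cc2ccc(C#N)cc2)c1O`, which carries a methyl in place of hydrogen on an aromatic carbon of compound 1: methyl in place of hydrogen on an aromatic carbon.

Among the compounds with values here, one measured step bears on this change. It is the same replacement made at another carbon of that ring, an at least 3.5-fold lower number from compound 1 to compound 2 (0.54 log units; beyond the scatter). With this single precedent, at a different place, a step of similar direction and modest size is expected in this assay, towards a lower number. Compound 3 may also remain at the limit, and the range is kept wide for that reason.

For compound 3 the expected value is 25000 nM, with an estimated range of 11000 nM to 50000 nM. The expected step is an at least 2.0-fold lower number from compound 1 to compound 3 (0.30 log units; that floor lies within the scatter).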

Compound 3, half-maximal inhibitory concentration: > 50000 nM
Compound 3 ended at the assay's limit; the forecaster's own chance of this, stated with the estimate: 30%; middle value at least 2.0-fold (0.30 log units) away from the limit.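

In this assay compound 3 gives > 50000 nM, a limit of the assay and not a number. Compound 1 gives > 50000 nM, also a limit. The step from compound 1 to compound 3 therefore cannot be read: the limit of > 50000 nM in this assay, at which 2 of the 3 values shown sit.

The compounds shown leave open whether the methyl para to a (diethylamino)methyl group in compound 3 shifts the value in this assay at all.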